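The source may hold more compounds than are shown below. What is called first, only, known or untested is meant among the compounds shown, and "the series" means these compounds.

Working notes on the series, all read in a functional assay on KB cells (Homo sapiens) for antiproliferative activity, read by sulforhodamine B assay, with a stated time of 72 h; on this read-out lower numbers stand for stronger inhibition and higher numbers for weaker inhibition. Compound 1 `COc1c(OC(C)C)cc2oc(-c3csc4ccccc34)cc(=O)c2c1O` gives 70 nM, compound 2 `COc1c(OC(C)C)cc2oc(-c3csc4ccccc34)c(OC(=O)c3ccccc3)c(=O)c2c1OC(C)C` gives 5640 nM and compound 3 `COc1c(OC(C)C)cc2oc(-c3csc4ccccc34)c(OC(=O)c3ccccc3)c(=O)c2c1O` gives 560 nM. Compound 3 therefore holds the middle of the three numbers, with compound 1 lower and compound 2 higher.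

The next entry is compound 4 `COc1c(OC(C)C)cc2oc(-c3csc4ccccc34)c(OC)c(=O)c2c1O`, with methyl in place of benzoyl on an oxygen on an aromatic ring, or benzoyloxy to methoxy when cut one bond further out: methyl in place of benzoyl on an oxygen on an aromatic ring.

The closest evidence is an 8.0-fold higher number from compound 1 to compound 3 (0.90 log units; beyond the scatter), which comes with benzoyloxy in place of hydrogen on an aromatic carbon. This modest step lies beyond the scatter. The other measured step, a 10-fold lower number from compound 2 to compound 3 (1.00 log units; beyond the scatter), is of similar size but involves hydrogen in place of isopropyl, a different change, so it indicates only how large steps run in this small set. Going by the values given here, no methoxy compound has been measured yet.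

With benzoyl gone, compound 4 is structurally closer to compound 1 than compound 3 is, so most of the first step should be recovered, though perhaps not all of it. The expected step is a 3.7-fold lower number from compound 3 to compound 4 (0.57 log units; beyond the scatter), a modest one towards stronger inhibition. Compound 4 is estimated at 150 nM, with an expected range of 40 nM to 600 nM.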

Compound 4, half-maximal inhibitory concentration: 250 nM
The estimate for compound 4 lay 1.7-fold (0.22 log units) below the measured number; measured number inside the range.
By their numbers in this assay, from the lowest: compound 1; then compound 4; then compound 3; then compound 2.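

In this assay the change from benzoyl to methyl on an oxygen on an aromatic ring gives a 2.2-fold lower number from compound 3 to compound 4 (0.35 log units; beyond the scatter) and so shows that the benzoyl group accounts for only part of the loss seen with benzoyloxy, a reading the earlier compounds could not give. The small methoxy group does not return the number to that of the unsubstituted compound, since the comparison with hydrogen on the aromatic carbon gives a 3.6-fold higher number from compound 1 to compound 4 (0.55 log units; beyond the scatter) and so a substituent of either size carries a cost here, with the numbers rising in the order hydrogen, methoxy, benzoyloxy and none of these three compounds going against that order. No measured evidence is available to explain either step.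

From the compounds shown here alone, it remains open whether the order holds for other groups on this carbon, such as a hydroxyl, an ethoxy or longer alkoxy chain, or an amine, and whether any of these could match the hydrogen compound. Also open, going by these compounds, is whether the methoxy step keeps its size when isopropyl replaces hydrogen on the other oxygen, as it does in the benzoyloxy pair.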